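The source may report more compounds than this note shows. Statements on the series, on what has been measured and on what is new or still open speak of the compounds shown alone.

Compound 1 `CC(C)[C@H](NC(=O)COc1cccc2ccccc12)C(=O)N[C@@H](CC(=O)O)C(=O)COc1ccccc1`: 14000 nM
Compound 2 `CC(C)[C@H](NC(=O)COc1cccc2ccccc12)C(=O)N[C@@H](CC(=O)O)C(=O)COc1ccc(C(F)(F)F)cc1`: > 100000 nM
Compound 3 `CC(C)[C@H](NC(=O)COc1cccc2ccccc12)C(=O)N[C@@H](CC(=O)O)C(=O)COc1ccc(C(N)=O)cc1`: > 100000 nM

All three were tested in a functional assay on Jurkat cells (Homo sapiens); a higher number here means a weaker inhibitor, a lower number a stronger inhibitor. Only compound 1 has a true number. Compound 2 gives > 100000 nM, which is a limit of the assay. Compound 3 gives > 100000 nM, which is also a limit and not a number. This is the limit of > 100000 nM in this assay, at which 2 of the 3 values shown sit.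

The next compound is compound 4 `CC(C)[C@H](NC(=O)COc1cccc2ccccc12)C(=O)N[C@@H](CC(=O)O)C(=O)COc1ccc(Oc2ccc(C(F)(F)F)cc2)cc1`, with 4-(trifluoromethyl)phenoxy in place of carbamoyl on an aromatic carbon.

Going by the values given here, two measured steps bear on this change: an at least 7.1-fold higher number from compound 1 to compound 2 (0.85 log units; beyond the scatter), and an at least 7.1-fold higher number from compound 1 to compound 3 (0.85 log units; beyond the scatter). Each puts a group in place of hydrogen on an aromatic carbon, and each ends at the limit. The step that the two limits leave unreadable from compound 2 to compound 3 offers no guidance. On the evidence of the first two steps, no recovery of inhibition is expected, so no readable change from the limit is anticipated in this assay.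

The expected move is a number no higher from compound 3 to compound 4 (the limit leaves the size open).

For compound 4 the estimate is 100000 nM, with an expected range of 20000 nM to 300000 nM.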

Compound 4, half-maximal inhibitory concentration: 9300 nM
Compound 4: middle estimate off by 11-fold (1.03 log units), on the high side, outside the stated range (below it).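

In this assay, 4-(trifluoromethyl)phenoxy at this aromatic carbon gives an at least 10-fold lower number from compound 3 to compound 4 (1.03 log units; beyond the scatter), and in place of trifluoromethyl it gives an at least 10-fold lower number from compound 2 to compound 4 (1.03 log units; beyond the scatter). Against hydrogen it gives a 1.5-fold lower number from compound 1 to compound 4 (0.18 log units; within the scatter), so a group at this carbon does not always cost inhibition, and compound 4 goes against the pattern set by compound 2 and compound 3. Both large steps start from a limit and not a number, so their true size stays open: the limit of > 100000 nM in this assay, at which 2 of the 4 values shown sit.

On these data alone, it remains open whether the return of inhibition depends on the phenoxy link, on the trifluoromethyl it carries, or on both. Plain phenoxy, or phenoxy carrying an amine or a carboxylic acid in place of trifluoromethyl, would separate these possibilities.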